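Swapping the chlorobenzyl arm on compound 1 for a thiourea

The compounds below may be only part of what the source reports. "The series", "measured", "known", "first", "only" and "open" are said of these compounds alone.

In a functional assay on HeLa cells (Homo sapiens) for antiproliferative activity, with a stated time of 24 h (a lower number here means a stronger inhibitor, a higher number a weaker inhibitor), compound 1 `NC(=O)c1c(NC(=O)c2ccccc2Cl)sc2c1CCN(Cc1ccccc1Cl)C2` gives 27500 nM. This is the lower of the two numbers recorded for the set. The nearest is compound 3 `NC(=O)c1c(NC(=O)c2ccccc2F)sc2c1CCN(Cc1c(Cl)cccc1Cl)C2`, which in this assay gives 33000 nM, a gap that stays within the usual scatter, so the two compounds cannot be ranked against each other. Compound 2 `Cc1ccc(C(=O)Nc2sc3c(c2C(N)=O)CCN(Cc2ccc(Cl)cc2Cl)C3)cc1` reaches only a limit of the assay, > 50000 nM, which is the limit of > 50000 nM in this assay, at which 1 of the 3 values shown sits.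

Compound 4 `CSc1ccccc1NC(=S)N1CCc2c(sc(NC(=O)c3ccccc3Cl)c2C(N)=O)C1` has not yet been measured in this assay. It differs from compound 1 in a single place: a group of 11 heavy atoms (8 carbon, 1 nitrogen, 2 sulfur; one six-membered aromatic ring of carbon only) in place of a group of 8 heavy atoms (7 carbon, 1 chlorine; one six-membered aromatic ring of carbon only), on an amine nitrogen in a ring. Among the measured compounds shown here, no pair of measured compounds shows a change of this kind, so no measured step points the way, and the three numbers recorded lie close to one another or at a limit. The account therefore expects a modest step in this assay, most likely toward a higher number, though a step no larger than the scatter would not be surprising. The step expected is a 1.4-fold higher number from compound 1 to compound 4 (0.14 log units; within the scatter). Compound 4 is thus estimated at 38000 nM, within a range from 12000 nM to 100000 nM.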

Compound 4, half-maximal inhibitory concentration: 43600 nM
The estimate for compound 4 lay 1.1-fold (0.06 log units) below the measured number; measured number inside the range.
By their numbers in this assay, from the lowest: compounds 1, 3 and 4 (each within the scatter of the next). At a limit, above all of these: compound 2.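

The thiourea arm carrying a 2-(methylthio)phenyl group on the amine nitrogen in the ring gives a 1.6-fold higher number from compound 1 to compound 4 (0.20 log units; within the scatter) in this assay, so compound 1 and compound 4 cannot be ranked against each other. Until now every compound shown carried a chlorinated benzyl arm on this nitrogen, and compound 4 is the first to show that a different kind of link can stand there without a step beyond the scatter. The exchange adds sulfur, nitrogen, a double bond outside aromatic rings and a hydrogen-bond donor to the arm, yet this single step does not separate the two numbers, and it says nothing about how much of the arm could be changed further.

From the compounds shown here alone, what a urea with oxygen in place of the thiourea sulfur, a simple acetyl group or a bare amine on this nitrogen would give remains open, as does whether the methylthio group on the phenyl ring plays any part. Nothing in the compounds shown gives a reason for this result.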